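Three pyrazole amines at the assay limit; a fourth awaits

This account rests on a few compounds, and the source may have more. Where it says the series, first, only, none or still open, it means among the compounds named here.

Compound 1 `Cc1[nH]nc(N)c1-c1cccc(Cl)c1` — in an assay on Sf9 cells for inhibition of mitogen-activated protein kinase kinase kinase 14 (Homo sapiens), read by ADP-Glo, with a stated time of 60 min (a higher number here means a weaker inhibitor, a lower number a stronger inhibitor), compound 1 gives > 100000 nM, a limit of the assay.
Compound 2 `Cc1[nH]nc(N)c1-c1cccc(C(F)(F)F)c1` — in this assay compound 2 gives > 100000 nM, again a limit.
Compound 3 `CC(=O)n1nc(C)c(-c2cccc(Cl)c2)c1N` — in this assay compound 3 gives > 100000 nM, also a limit.

The three measured compounds therefore sit together at the limit of > 100000 nM in this assay, at which 3 of the 3 values shown sit, and none of them yields a number. The change from compound 1 to compound 2 is trifluoromethyl in place of chloro on an aromatic carbon, and the step it produced, a step that the two limits leave unreadable from compound 1 to compound 2, cannot be read because both ends are limits. Compound 3 carries the chloro on a different core; how the core of compound 3 differs from the core of compound 1 is not broken down here.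

Compound 4 `CC(=O)n1nc(C)c(-c2cccc(C(F)(F)F)c2)c1N` is not yet measured. It differs from compound 3 by trifluoromethyl in place of chloro on an aromatic carbon, the same kind of change as that from compound 1 to compound 2, though here the position is described as meta to a large group rather than meta to a group of 7 heavy atoms. Since compound 3 itself gives only a limit, the step that the limit leaves unreadable from compound 3 to compound 4 is expected to leave compound 4 at the limit as well. Compound 4 is estimated at 200000 nM in this assay, between 100000 nM and 1000000 nM.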

Compound 4, half-maximal inhibitory concentration: > 100000 nM
Compound 4: no number, only a limit (the forecaster's own chance of this, stated with the estimate: 90%); the middle value does not contradict the limit.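

In this assay compound 4 gives only a limit, as compound 3 does, so no new step can be read between these two compounds. The compounds shown leave open which structural change, if any, would bring a readable number, with every compound so far sitting at the same limit: the limit of > 100000 nM in this assay, at which 4 of the 4 values shown sit.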